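The source may hold more compounds than are shown below. What is called first, only, known or untested is meant among the compounds shown, and "the series" means these compounds.

Measured compounds:
compound 1, `C=CCn1c(SCC(=O)c2ccccc2)nnc1-c1ccccc1` — 66%
compound 2, `O=C(CSc1nnc(-c2ccccc2)n1-c1ccccc1)c1ccccc1` — 68%
compound 3, `C=CCn1c(SC/C(=N/O)c2ccccc2)nnc1-c1cc(OC)c(OC)c(OC)c1` — 73%

In a functional assay on the whole organism (strain albino) for inhibition, with Rattus norvegicus as the target, read by paw edema, with a stated time of 4 h, at a dose of 0.28 mmol/kg by the oral route (on this read-out lower numbers stand for less inhibition and higher numbers for more inhibition at the one dose given (going by the name of the read-out)), compound 1 gives 66%, compound 2 gives 68% and compound 3 gives 73%; all three lie within the usual scatter of one another. Compound 1 and compound 2 differ in one place, (phenyl in place of allyl on an aromatic nitrogen), and this change made a number 2 percentage points higher from compound 1 to compound 2 (within the scatter). The unmeasured compound 4, `COc1cc(-c2nnc(SC/C(=N/O)c3ccccc3)n2-c2ccccc2)cc(OC)c1OC`, stands to compound 3 in the same kind of way: phenyl in place of allyl on an aromatic nitrogen. The surroundings are not identical, though: in compound 1 the ring nitrogen is next to the ring atom that bears a large group and next to the ring atom that bears a phenyl group, whereas in compound 3 it is next to two ring atoms that each bear a large group, so this is the same kind of change rather than the same change. How the core of compound 3 differs from the core of compound 1 is not broken down here.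

In this assay a small step is expected, a number 1 percentage points lower from compound 3 to compound 4 (within the scatter), because the earlier change from allyl to phenyl gave a number 2 percentage points higher from compound 1 to compound 2 (within the scatter). Compound 4 is therefore expected to give about 72%, estimated to fall between 60% and 83%.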

Compound 4, a percentage reported as inhibition, in the whole organism at one dose (the size of the read-out at that dose, not a potency): 76%
Beside the measured number, compound 4's estimate is 4 percentage points below it, within the range that was stated.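

In this assay, putting phenyl in place of allyl on an aromatic nitrogen gives a number 3 percentage points higher from compound 3 to compound 4 (within the scatter). Set beside the earlier case, the change behaves alike on the two cores: the same change on two cores in this assay, a number 2 percentage points higher (within the scatter) from compound 1 to compound 2 and a number 3 percentage points higher (within the scatter) from compound 3 to compound 4, 1 percentage points apart, within the scatter of two such steps. This shows that the swap left the read-out within the scatter on both cores, but it does not show that phenyl truly raises inhibition, nor that the same would hold on a third core.

The compounds shown leave open what other groups on that aromatic nitrogen would do, such as methyl, benzyl or a longer chain ending in an amine. They also leave open whether these compounds would separate at other doses.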